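A few compounds are considered here, and "the series" means these few. Any claim that something is new, unique, unknown or untested is made for them only; others in the source may bear on it.

Compound 1 `C=CCN(CC)S(=O)(=O)NC(=O)Nc1c(C(C)C)cccc1C(C)C` stands second highest among three numbers in an assay on liver for inhibition of sterol O-acyltransferase 1 (Rattus norvegicus), using microsomes (on this read-out lower numbers stand for stronger inhibition and higher numbers for weaker inhibition), where compound 1 gives 2100 nM. Compound 2 `CCCCCCN(CCCCCC)S(=O)(=O)NC(=O)Nc1c(C(C)C)cccc1C(C)C` gives 510 nM in this assay, and compound 3 `CC(C)c1cccc(C(C)C)c1NC(=O)NS(=O)(=O)Nc1c(C(C)C)cccc1C(C)C` gives 11000 nM. Compound 4 `CCCCCCC(C)OS(=O)(=O)NC(=O)Nc1c(C(C)C)cccc1C(C)C` has not been measured; it differs from compound 1 in one place: (1-methylheptyl)oxy in place of allyl(ethyl)amino on a sulfonyl sulfur. Within the data shown here, no step between measured compounds is recorded, so the size of this move cannot be read off directly. Because compound 2 gives 510 nM while compound 1 gives 2100 nM, a modest step to a lower number is expected in this assay, though it may remain within the scatter. Compound 4 is therefore estimated at 900 nM, within 250 nM to 3200 nM. That estimate means an expected step of a 2.3-fold lower number from compound 1 to compound 4 (0.37 log units; beyond the scatter).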

Compound 4, half-maximal inhibitory concentration: 35000 nM
For compound 4 the middle estimate is 39-fold (1.59 log units) below the measured one, and the stated range ends below it.
By their numbers in this assay, from the lowest: compound 2; then compound 1; then compound 3; then compound 4.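

In this assay, (1-methylheptyl)oxy in place of allyl(ethyl)amino on a sulfonyl sulfur gives a 17-fold higher number from compound 1 to compound 4 (1.22 log units; beyond the scatter), a large step. Among these compounds, all the earlier compounds carried an amino group at this position, and this step shows that the read-out can respond strongly to what is attached to the sulfur there. Among the compounds shown here, the change replaces the linking atom and the chain together, so the single step does not separate the two, and nothing available explains it. From the compounds shown here alone, whether a (1-methylheptyl)amino group or a shorter ethoxy group would give a similar number remains open.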